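A few compounds are considered here, and "the series" means these few. Any claim that something is new, unique, unknown or untested is made for them only; others in the source may bear on it.

Measured compounds:
- compound 1, `C=C1[C@@H](OC(C)=O)C[C@@H]2[C@](C)(CO[Si](C)(C)C(C)(C)C)[C@H](OC(C)=O)CC[C@@]2(C)[C@@H]1C[C@@H](Nc1ccccc1)C1=CCOC1=O`, with 5710 nM
- compound 2, `C=C1[C@@H](OC(C)=O)C[C@@H]2[C@](C)(COC=O)[C@H](OC(C)=O)CC[C@@]2(C)[C@@H]1C[C@@H](Nc1cccc2ccccc12)C1=CCOC1=O`, with 32300 nM
- compound 3, `C=C1[C@@H](OC(C)=O)C[C@@H]2[C@](C)(COC=O)[C@H](OC(C)=O)CC[C@@]2(C)[C@@H]1C[C@@H](Nc1ccccc1)C1=CCOC1=O`, with 32100 nM

These three compounds share one core and were tested in a functional assay on KB cells (Homo sapiens) for cytotoxicity, read by sulforhodamine B assay; on this read-out higher numbers stand for weaker inhibition and lower numbers for stronger inhibition. Compound 1 gives the lowest of the three numbers in this assay. Its nearest neighbour is compound 3: a 5.6-fold higher number from compound 1 to compound 3 (0.75 log units; beyond the scatter). Compound 2 and compound 3 differ in the group on the amine nitrogen, and that change leaves the number where it was: a 1.0-fold lower number from compound 2 to compound 3 (0.00 log units; within the scatter).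

Compound 4, `C=C1[C@@H](OC(C)=O)C[C@@H]2[C@](C)(CO[Si](C)(C)C(C)(C)C)[C@H](OC(C)=O)CC[C@@]2(C)[C@@H]1C[C@@H](Nc1ccccc1C(=O)O)C1=CCOC1=O`, has not yet been measured. It differs from compound 1 in one place: carboxy in place of hydrogen on an aromatic carbon. Among the compounds with values here, no measured step alters the ring on the amine nitrogen in this way; the only step touching that ring is the one from compound 2 to compound 3, which stays within the scatter. Nothing in the data points to a step beyond the scatter for this change, so the number for compound 4 is expected to stay near that of compound 1, with the change estimated as a 1.1-fold higher number from compound 1 to compound 4 (0.06 log units; within the scatter). Compound 4 is therefore estimated at 6500 nM, within a range from 2000 nM to 25000 nM.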

Compound 4, half-maximal inhibitory concentration: 6050 nM
The estimate for compound 4 lay 1.1-fold (0.03 log units) above the measured number; the range from low to high includes it.
By their numbers in this assay, from the lowest: compounds 1 and 4 (each within the scatter of the next); then compounds 3 and 2 (each within the scatter of the next).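

In this assay, putting a carboxy group on the phenyl ring of compound 1 gives a 1.1-fold higher number from compound 1 to compound 4 (0.03 log units; within the scatter), so this added group leaves the number unchanged within the scatter. The earlier compounds shown here showed only that phenyl and naphthalen-1-yl could be exchanged on the amine nitrogen; this result adds that a substituent on the phenyl ring, at a place ortho to a large group, also produces no step beyond the scatter, and it does so with the silicon-bearing group in place. Nothing shown gives a measured reason for this flat result.

On these data alone, it remains open whether an amine, a hydroxyl or a methyl ester at the same place would also leave the number unchanged. As far as these compounds go, whether carboxy has the same outcome alongside the smaller oxygen group of compound 3 also remains open.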